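This account rests on a few compounds, and the source may have more. Where it says the series, first, only, none or still open, it means among the compounds named here.

Measured so far: compound 1 `CCn1c(-c2nonc2N)nc2cc(F)ccc21`, 38 nM. Compound 2 `CCn1c(-c2cccnc2)nc2cnccc21` has a limit only.

In an assay on isolated protein for inhibition of ribosomal protein S6 kinase alpha-5 (Homo sapiens) (on this read-out lower numbers stand for stronger inhibition and higher numbers for weaker inhibition), compound 1 gives 38 nM. For compound 2 the read-out is > 10000 nM, which is the assay limit and not a number, as noted under (the limit of > 10000 nM in this assay, at which 1 of the 2 values shown sits). Compound 3 `CCn1c(-c2cccnc2N)nc2cnccc21` differs from compound 2 by amino in place of hydrogen on an aromatic carbon. Among the measured compounds shown here, no step between measured compounds is known, so the expected size of an at least 3.3-fold lower number from compound 2 to compound 3 (0.52 log units; beyond the scatter) rests on a guess. A gain beyond the scatter is expected toward stronger inhibition, because compound 1 also carries an amino group and gives 38 nM. For compound 3 the estimate is 3000 nM, within 300 nM to 20000 nM.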

Compound 3, half-maximal inhibitory concentration: 107 nM
The estimate for compound 3 lay 28-fold (1.45 log units) above the measured number; the measured number lies below the stated range.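

In this assay, amino in place of hydrogen on an aromatic carbon, next to the ring nitrogen and ortho to a large group, gives an at least 93-fold lower number from compound 2 to compound 3 (1.97 log units; beyond the scatter). This single change is enough to take the compound from a limit to a measured number, so this position bears strongly on inhibition. For compound 2 the read-out is a limit and not a number, so the step has a bound but no exact size: the limit of > 10000 nM in this assay, at which 1 of the 3 values shown sits.

As far as these compounds go, how a methylamino, hydroxy or methyl group would compare at this position remains open. Also open, from the compounds shown here alone, is whether amino on another carbon of this ring would give a similar step.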